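Aryl urea on a nitrile-bearing aziridine: fluoro to trifluoromethyl

The source may report more compounds than this note shows. Statements on the series, on what has been measured and on what is new or still open speak of the compounds shown alone.

Measured so far:
compound 1, `CCOC(=O)CNC(=O)N1CC1C#N`, 17000 nM
compound 2, `CCCCNC(=O)N1CC1C#N`, 6700 nM
compound 3, `N#CC1CN1C(=O)Nc1ccc(F)cc1`, 2400 nM

All three share one core and differ only in the group attached to the urea nitrogen. In a functional assay on MCF7 cells (Homo sapiens) for inhibition (on this read-out lower numbers stand for stronger inhibition and higher numbers for weaker inhibition), compound 3 gives 2400 nM, the lowest of the three numbers. Compound 2 stands above it by more than the scatter, and compound 1 stands further away still.

Compound 4, `N#CC1CN1C(=O)Nc1ccc(C(F)(F)F)cc1`, is the next step. The change is trifluoromethyl in place of fluoro on an aromatic carbon, at the position para to a group of 8 heavy atoms. Going by the values given here, no pair with a comparable change has been measured here, so there is no step to lean on. The change from compound 3 to compound 4 is expected to stay small, within or near the scatter, as a 1.3-fold lower number from compound 3 to compound 4 (0.12 log units; within the scatter). Compound 4 is therefore estimated at 1800 nM, between 600 nM and 6000 nM.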

Compound 4, half-maximal inhibitory concentration: 1400 nM
Estimate against measurement, compound 4: 1.3-fold (0.11 log units) above; low and high end bracket the measured number.
By their numbers in this assay, from the lowest: compounds 4 and 3 (each within the scatter of the next); then compound 2; then compound 1.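

Putting trifluoromethyl in place of fluoro on an aromatic carbon, para to a group of 8 heavy atoms, gives a 1.7-fold lower number from compound 3 to compound 4 (0.23 log units; within the scatter) in this assay. Going by these compounds alone, this is the first direct step between two compounds that differ in one place, as the earlier compounds offered none. It shows that this position can carry a group of 4 heavy atoms instead of 1 with a step that stays within the scatter.

Going by these compounds, whether an amine, a carboxylic acid or a methoxy group at this position would give a step beyond the scatter remains open. Nothing available here links this step to any property of either group.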